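The source may hold more compounds than are shown below. What is called first, only, known or untested is meant among the compounds shown, and "the series" means these compounds.

In a functional assay on the whole organism (blood, strain albino) with Mus musculus as the target, with stated times of 6 days and 4 h, at a dose of 0.4 mmol/kg by the oral route (a lower number here means less inhibition, a higher number more inhibition at the dose given (going by the name of the read-out)), the measured compounds stand as follows.

Compound 1 `Cc1cc(C(=O)O)nn1-c1ccc(S(=O)(=O)NC(=S)NC2CCCCC2)cc1` gives 1%.
Compound 2 `CCNC(=S)NS(=O)(=O)c1ccc(-n2nc(C(=O)O)cc2C)cc1` gives -2%.
Compound 3 `Cc1cc(C)n(-c2ccc(S(=O)(=O)NC(=S)NC3CCCCC3)cc2)n1` gives only a limit of the assay, < 2%.

Compound 2 differs from compound 1 by one change, (ethyl in place of cyclohexyl on an amide-type nitrogen), and that change made a step of a number 3 percentage points lower from compound 1 to compound 2 (within the scatter). The core of compound 3 differs from the core of compound 1 by methyl in place of carboxy on an aromatic carbon; the step that the limit leaves unreadable from compound 1 to compound 3 cannot be sized, because compound 3 sits at the limit of < 2% in this assay, at which 1 of the 3 values shown sits.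

Compound 4 `CCNC(=S)NS(=O)(=O)c1ccc(-n2nc(C)cc2C)cc1` is not yet measured. It differs from compound 3 by ethyl in place of cyclohexyl on an amide-type nitrogen, the same change that led from compound 1 to compound 2, at a place described in the same words. On the core of compound 1 that change stayed within the scatter, so from compound 3 to compound 4 a step that the limit leaves unreadable from compound 3 to compound 4 is expected, resting on a number 3 percentage points lower from compound 1 to compound 2 (within the scatter). Compound 4 is therefore estimated at 0%, between -8% and 6%.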

Compound 4, a percentage reported as inhibition, in the whole organism at one dose (the size of the read-out at that dose, not a potency): 0%
Compound 4: middle estimate and measured number agree at the digits printed; measured number inside the range.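

Compound 3 stands at a limit of the assay and not at a number, so the steps that touch it cannot be read, including ethyl in place of cyclohexyl on its core: the limit of < 2% in this assay, at which 1 of the 4 values shown sits. Among the compounds shown here, the one new step that can be read concerns the other change, methyl in place of carboxy, which with ethyl on the amide-type nitrogen gives a number 2 percentage points higher from compound 2 to compound 4 (within the scatter). This shows no effect that could be carried from one core to another, and it does not show that ethyl in place of cyclohexyl acts alike on both cores, since that change can be sized only on the core of compound 1.

Going by these compounds, it remains open whether a longer chain or a phenyl group on the amide-type nitrogen would move the inhibition beyond the scatter in this assay. The same question stands for an amine or an ester on the aromatic carbon that holds the carboxy or methyl group.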